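The source may hold more compounds than are shown below. What is called first, only, known or untested is meant among the compounds shown, and "the series" means these compounds.

Compound 2 `COC(=O)C(=O)CNC1=CS(=O)(=O)O[C@@]12[C@@H](CO[Si](C)(C)C(C)(C)C)O[C@@H](n1cc(C)c(=O)n(C)c1=O)[C@@H]2O[Si](C)(C)C(C)(C)C` is one of three compounds whose cytotoxicity was measured in a functional assay on CCRF-CEM cells (Homo sapiens); on this read-out lower numbers stand for higher toxicity in this test and higher numbers for lower toxicity in this test. Compound 2 gives 5570 nM, the second highest of the three numbers. Among the compounds with values here, its nearest neighbour is compound 1 `Cc1cn([C@@H]2O[C@H](CO[Si](C)(C)C(C)(C)C)[C@@]3(OS(=O)(=O)C=C3NC(=O)c3ccccc3)[C@H]2O[Si](C)(C)C(C)(C)C)c(=O)n(C)c1=O`, which gives 4910 nM in this assay; the single step between them, a 1.1-fold higher number from compound 1 to compound 2 (0.05 log units; within the scatter), lies within the scatter. Within the data shown here, the furthest is compound 3 `Cc1cn([C@@H]2O[C@@H]3COC4(O)CS(=O)(=O)O[C@@]34[C@H]2O[Si](C)(C)C(C)(C)C)c(=O)[nH]c1=O`, which gives 100000 nM in this assay, a gap that is beyond the scatter; compound 3 differs from compound 2 in several places at once, so no single step is drawn between them.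

Compound 4 `Cc1cn([C@@H]2O[C@H](CO[Si](C)(C)C(C)(C)C)[C@@]3(OS(=O)(=O)C=C3NCC(=O)C(N)=O)[C@H]2O[Si](C)(C)C(C)(C)C)c(=O)n(C)c1=O` has not yet been measured. It differs from compound 2 in one place: amino in place of methoxy on a carbonyl carbon. Among the measured compounds shown here, the only measured step that bears on this part of the molecule is the one from compound 1 to compound 2, where a larger exchange of the whole group on the amine nitrogen produced no change beyond the scatter. The exchange of methoxy for amino on the carbonyl carbon is smaller still, so no step beyond the scatter is expected in this assay. Compound 4 is therefore estimated at 6000 nM, with a range from 2500 nM to 15000 nM, which means an expected step of a 1.1-fold higher number from compound 2 to compound 4 (0.03 log units; within the scatter).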

Compound 4, half-maximal cytotoxic concentration: 9960 nM
Estimate against measurement, compound 4: 1.7-fold (0.22 log units) below; low and high end bracket the measured number.
By their numbers in this assay, from the lowest: compounds 1, 2 and 4 (each within the scatter of the next, the first and the last beyond it); then compound 3.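

In this assay, the exchange on the carbonyl carbon gives a 1.8-fold higher number from compound 2 to compound 4 (0.25 log units; within the scatter), so turning the methoxycarbonyl end of the side chain into a carbamoyl end, with amino bringing a hydrogen-bond donor in place of a hydrogen-bond acceptor, does not move the read-out beyond the scatter. Set against the original benzoyl on the amine nitrogen, however, the new group gives a 2.0-fold higher number from compound 1 to compound 4 (0.31 log units; beyond the scatter), a modest step and the first exchange at this nitrogen that is printed as beyond the scatter, so the group held there is not entirely without consequence for the number. No measurement at hand explains either step.

The compounds shown leave open what a carboxylic acid or a dimethylamino group on that carbonyl carbon would give, and whether a longer chain on the amine nitrogen would carry the number further in the same direction. They also leave open how the number of compound 3, 100000 nM, relates to any single place, since that compound differs from the others in several places at once.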